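Thiophene for Isoxazole: Expected Effect on Serum Free Fraction

The source may hold more compounds than are shown below. What is called first, only, known or untested is meant among the compounds shown, and "the series" means these compounds.

Of the compounds shown here, three sharing one core have been measured in an ADME assay on the whole organism (serum, Rattus norvegicus) for protein binding; on this read-out lower numbers stand for a smaller free fraction and higher numbers for a larger free fraction. Compound 1 `CNC(=O)c1ccc(C(=O)C2=C(O)C(=O)N(c3ccc(-c4ccon4)cc3)C2C2CCCCC2)cc1` gives 0.007, compound 2 `COc1ccc(C(=O)C2=C(O)C(=O)N(c3ccc(-c4ccon4)cc3)C2C2CCCCC2)cn1` gives 0.003, and compound 3 `CC(C)(C)C(=O)C1=C(O)C(=O)N(c2ccc(-c3ccon3)cc2)C1c1ccccc1OCCO` gives 0.012. Compound 3 shows the highest of the three numbers, although its gap to compound 1 lies within the scatter and only its gap to compound 2 lies beyond it. For the measured compounds named here, the one measured step, a 2.3-fold lower number from compound 1 to compound 2 (0.37 log units; beyond the scatter), concerns a change on the carbonyl carbon. Compound 4 `CC(C)(C)C(=O)C1=C(O)C(=O)N(c2ccc(-c3ccsc3)cc2)C1c1ccccc1OCCO` instead carries thiophen-3-yl in place of 1,2-oxazol-3-yl on an aromatic carbon. Going by the values given here, no measured step touches this position, so there is no direct guide. The expected step is a 1.3-fold lower number from compound 3 to compound 4 (0.12 log units; within the scatter), small and within the usual scatter. Compound 4 is estimated at 0.009, with a range from 0.004 to 0.02.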

Compound 4, unbound fraction: 0.002
Beside the measured number, compound 4's estimate is 4.5-fold (0.65 log units) above it; measured number below the stated range.
By their numbers in this assay, from the lowest: compounds 4 and 2 (each within the scatter of the next); then compounds 1 and 3 (each within the scatter of the next).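

In this assay this position proves sensitive: thiophen-3-yl in place of 1,2-oxazol-3-yl gives a 6.0-fold lower number from compound 3 to compound 4 (0.78 log units; beyond the scatter) even though one five-membered aromatic ring simply replaces another. For the compounds shown here, the only earlier step lay on a carbonyl carbon, so this is the first sign that the group at this position also shifts the free fraction. No measurement shown here explains the drop. From the compounds shown here alone, whether the same swap would act alike in compound 1 remains open, as does what an amine or a carboxylic acid at this position would give.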